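Inverting the Carbinol Stereocentre of a Hydroxybutynyl Oxindole

The compounds below may be only part of what the source reports. "The series", "measured", "known", "first", "only" and "open" are said of these compounds alone.

compound 1 `COc1cc[nH]c1/C=C1\C(=O)Nc2ccc(F)c(I)c21` — > 30000 nM
compound 2 `COc1cc[nH]c1/C=C1\C(=O)Nc2ccc(F)c(C#C[C@@H](C)O)c21` — 110 nM

In a functional assay on MDA-MB-435 cells (Homo sapiens) for inhibition (a higher number here means a weaker inhibitor, a lower number a stronger inhibitor), compound 1 shows only a limit, not a number, namely (the limit of > 30000 nM in this assay, at which 1 of the 2 values shown sits). Compound 2 gives 110 nM in this assay, the only number shown. Going by the values given here, the single measured step is an at least 270-fold lower number from compound 1 to compound 2 (2.43 log units; beyond the scatter). Compound 3 `COc1cc[nH]c1/C=C1\C(=O)Nc2ccc(F)c(C#C[C@H](C)O)c21` differs from compound 2 thus: the two compounds have the same atoms and bonds and differ only in configuration as drawn: 1 of 2 stereo elements differ; a stereocentre at a saturated chain carbon is drawn R in compound 2 and S in compound 3. That measured step exchanged a whole group rather than a configuration, so it does not bear directly on this change; compound 3 is expected to stay close to compound 2, with at most a modest weakening, a 2.0-fold higher number from compound 2 to compound 3 (0.30 log units; within the scatter). Compound 3 is thus estimated at 220 nM, between 60 nM and 900 nM.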

Compound 3, half-maximal inhibitory concentration: 190 nM
Compound 3: middle estimate off by 1.2-fold (0.06 log units), on the high side; the range from low to high includes it.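

In this assay, inverting the carbinol stereocentre gives a 1.7-fold higher number from compound 2 to compound 3 (0.24 log units; within the scatter), which lies within the scatter, so the R and S forms of the 3-hydroxybut-1-yn-1-yl group cannot be told apart here. The large step away from iodo therefore holds for the S form as well: an at least 150-fold lower number from compound 1 to compound 3 (2.19 log units; beyond the scatter), beyond the scatter. Its starting point, compound 1, is a limit and not a number: the limit of > 30000 nM in this assay, at which 1 of the 3 values shown sits.

Still open, going by these compounds, is whether the hydroxyl itself is needed. An amine or a carboxylic acid in its place, or a longer chain, would address this.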